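The source may hold more compounds than are shown below. What is called first, only, known or untested is meant among the compounds shown, and "the series" means these compounds.

Compound 1 `O=C(O)c1csc([C@H]2CC[C@@H]3[C@@H](COc4ccccc4F)[C@H](O)C[C@@H]3O2)n1` gives > 10000 nM in an assay on HEK293 cells for agonist activity at prostaglandin E2 receptor EP2 subtype (Homo sapiens), read by a beta-galactosidase reporter and beta-arrestin recruitment, with a stated time of 90 min; on this read-out lower numbers stand for an effect already at smaller amounts and higher numbers for an effect only at larger amounts of compound; this value is a limit of the assay, not a number.
Compound 2 `Cc1cccc(OC[C@@H]2[C@H]3CC[C@H](c4nc(C(=O)O)cs4)O[C@H]3C[C@H]2O)c1` gives > 10000 nM in this assay; this too is a limit of the assay, not a number.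

Compound 2 therefore stands at the limit of this assay, where (the limit of > 10000 nM in this assay, at which 2 of the 2 values shown sit), and no measured number places it more exactly. Among the measured compounds shown here, the one measured step, a step that the two limits leave unreadable from compound 1 to compound 2, exchanges 2-fluorophenyl for 3-methylphenyl on an oxygen on a saturated carbon, and its size cannot be read, since both of its ends are limits.

Compound 3 `O=C(O)c1csc([C@H]2CC[C@@H]3[C@@H](COc4ccccc4Cl)[C@H](O)C[C@@H]3O2)n1` differs from compound 2 by 2-chlorophenyl in place of 3-methylphenyl on an oxygen on a saturated carbon. The only measured step that bears on a change at this oxygen is the unreadable one from compound 1 to compound 2, so it gives no direction and no size for the new exchange, and nothing in the numbers shown argues for a shift beyond the scatter. Compound 3 is therefore expected to sit at or near the limit of this assay, with an estimated value of 15000 nM between 5000 nM and 50000 nM. The step that the limit leaves unreadable from compound 2 to compound 3 is accordingly expected to be small, and the most likely outcome is that the assay again reports only a limit.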

Compound 3, half-maximal effective concentration: 203 nM
Beside the measured number, compound 3's estimate is 74-fold (1.87 log units) above it; the whole stated range lies above it.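

The position on the oxygen on a saturated carbon can carry a measurable effect in this assay, where a lower number means that less compound is needed. Putting 2-chlorophenyl there in place of 3-methylphenyl gives an at least 49-fold lower number from compound 2 to compound 3 (1.69 log units; beyond the scatter). The comparison with the smallest structural change is chloro in place of fluoro on an aromatic carbon, which gives an at least 49-fold lower number from compound 1 to compound 3 (1.69 log units; beyond the scatter), so a change of one atom on the phenyl ring is enough to separate a compound with a measured number from one that gives none. Compound 1 and compound 2 each give only a limit of the assay, not a number, and the step between them cannot be read: the limit of > 10000 nM in this assay, at which 2 of the 3 values shown sit.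

From the compounds shown here alone, each of the two new steps has only one measured end, so how large they truly are remains open, and the chloro group's advantage over fluoro and methyl cannot yet be given as an exact size. Also open, going by these compounds, is whether a bromo or a methoxy group in place of the chloro on an aromatic carbon would keep, raise or lose the effect seen with compound 3.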